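Working notes: aryl changes on the ring amine nitrogen

The source may report more compounds than this note shows. Statements on the series, on what has been measured and on what is new or still open speak of the compounds shown alone.

Measured so far in an assay on CHO cells for displacement of a labelled ligand from adenosine receptor A3 (Homo sapiens), read by scintillation counting, with a stated time of 120 min, tested at 10 uM; a higher number here means more inhibition at the concentration tested (going by the name of the read-out), a lower number less inhibition:
compound 1 `CC(C)N1CCN(Cc2csc(N)c2C(=O)c2ccc(Cl)cc2)CC1` gives 0%;
compound 2 `Nc1scc(CN2CCN(c3cccc(C(F)(F)F)c3)CC2)c1C(=O)c1ccc(Cl)cc1` gives 0%;
compound 3 `Nc1scc(CN2CCN(c3cccc(F)c3F)CC2)c1C(=O)c1ccc(Cl)cc1` gives 0%.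

Compound 3 stands level with compounds 1 and 2 in this assay; the three values sit together within the scatter. The steps of no change at the digits printed from compound 1 to compound 2 (within the scatter), no change at the digits printed from compound 1 to compound 3 (within the scatter) and no change at the digits printed from compound 2 to compound 3 (within the scatter) show that swapping the group on the amine nitrogen in a ring among these three options has left the read-out unchanged at the digits printed.

Compound 4 `Nc1scc(CN2CCN(c3cc(Cl)ccc3Cl)CC2)c1C(=O)c1ccc(Cl)cc1` differs from compound 3 by 2,5-dichlorophenyl in place of 2,3-difluorophenyl on an amine nitrogen in a ring. All three measured steps bear on this change, since each also exchanges the group on that ring nitrogen, and each was flat. The step of no change at the digits printed from compound 3 to compound 4 (within the scatter) is therefore expected to be none beyond the scatter. For compound 4 in this assay the estimate is 0%, with a range from -10% to 15%.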

Compound 4, a percentage reported as inhibition, at one concentration (the size of the read-out at that concentration, not a potency): 1%
Estimate against measurement, compound 4: 1 percentage points below, within the range that was stated.
By their numbers in this assay, from the lowest: compounds 1, 2, 3 and 4 (each within the scatter of the next).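

In this assay, a 2,5-dichlorophenyl group on the ring amine nitrogen also leaves the read-out flat: a number 1 percentage points higher from compound 3 to compound 4 (within the scatter), a number 1 percentage points higher from compound 2 to compound 4 (within the scatter) and a number 1 percentage points higher from compound 1 to compound 4 (within the scatter). The chlorine-bearing aryl group thus joins isopropyl, 3-(trifluoromethyl)phenyl and 2,3-difluorophenyl as a further group at this position with no step beyond the scatter. Nothing available bears on why this position stays flat.

Open, going by these compounds, is whether a carboxylic acid or a longer alkyl chain on this nitrogen would shift the read-out. Changes elsewhere on the shared core also remain open.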